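This account rests on a few compounds, and the source may have more. Where it says the series, first, only, none or still open, it means among the compounds named here.

Compound 3 `C[C@H]1C[C@H]1C(=O)N1CC2CC(C1)N2` stands second highest of the three numbers in an assay on SH-EP1 cells for agonist activity at Neuronal acetylcholine receptor; alpha4/beta2 (Homo sapiens), read by FLIPR and calcium flux (a higher number here means a larger maximal response, a lower number a smaller maximal response), with compound 3 giving 87%; its nearest neighbour is compound 1 `CC(C)C(=O)N1CC2CC(C1)N2`, which gives 86%, and the furthest is compound 2 `O=C([C@@H]1C[C@@H]1F)N1CC2CC(C1)N2`, which gives 120%. The measured steps are a number 1 percentage points higher from compound 1 to compound 3 (within the scatter), a number 34 percentage points higher from compound 1 to compound 2 (beyond the scatter) and a number 33 percentage points lower from compound 2 to compound 3 (beyond the scatter). Compound 4 `C[C@@H]1C[C@H]1C(=O)N1CC2CC(C1)N2` differs from compound 3 only as follows: the two compounds have the same atoms and bonds; at least one stereo element is drawn with a configuration in one of them and without one in the other: 1 of 4 stereo elements differ; a stereocentre at a saturated ring carbon is drawn S in compound 3 and R in compound 4. Among the compounds with values here, none of the measured steps concerns a change of configuration alone; each replaces one group with another. So no measured step bears directly on this change, and compound 4 is expected to show a step of no change at the digits printed from compound 3 to compound 4 (within the scatter) in this assay, that is, none beyond the scatter. Compound 4 is therefore estimated at 87%, with a range from 65% to 110%.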

Compound 4, largest response reached (Emax), in percent of the reference or control that the assay uses: 110%
Beside the measured number, compound 4's estimate is 23 percentage points below it; measured number inside the range.
By their numbers in this assay, from the lowest: compounds 1 and 3 (each within the scatter of the next); then compounds 4 and 2 (each within the scatter of the next).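

Inverting one stereocentre at a saturated ring carbon, from S to R, is enough to shift the response in this assay, giving a number 23 percentage points higher from compound 3 to compound 4 (beyond the scatter). The 2-methylcyclopropyl group in place of isopropyl therefore depends on configuration: with the R centre it gives a number 24 percentage points higher from compound 1 to compound 4 (beyond the scatter), whereas compound 3 lies within the scatter of compound 1. Methyl in place of fluoro in this configuration gives a number 10 percentage points lower from compound 2 to compound 4 (within the scatter).

As far as these compounds go, whether the same inversion matters in the 2-fluorocyclopropyl series, or with ethyl or methoxy on the cyclopropyl ring, remains open. The reading of this inversion also carries a limit: the fact that one of compounds 3 and 4 is drawn with a defined configuration and the other without, at the place where they differ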